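Methyl on the Ring Nitrogen of Compound 1

The source may report more compounds than this note shows. Statements on the series, on what has been measured and on what is new or still open speak of the compounds shown alone.

Compound 1 `O=C(Nc1ccc(Oc2ccnc3[nH]ccc23)c(F)c1)c1cc2cccnc2n(-c2ccccc2)c1=O` stands second highest of the three numbers in a functional assay on HT-29 cells (Homo sapiens) for antiproliferative activity, read by MTT assay, with a stated time of 72 h (a higher number here means a weaker inhibitor, a lower number a stronger inhibitor), where compound 1 gives 160 nM. Compound 2 `O=C(Nc1ccc(Oc2ccnc3[nH]ccc23)c(F)c1)c1cc2cccnc2n(-c2ccc(F)cc2)c1=O` gives 36 nM, a change summed up as a 4.4-fold lower number from compound 1 to compound 2 (0.65 log units; beyond the scatter). Compound 3 `COc1ccc(-n2c(=O)c(C(=O)Nc3ccc(Oc4ccnc5[nH]ccc45)c(F)c3)cc3cccnc32)cc1` gives 540 nM, which is a 3.4-fold higher number from compound 1 to compound 3 (0.53 log units; beyond the scatter); against compound 2 it reads a 15-fold higher number from compound 2 to compound 3 (1.18 log units; beyond the scatter). Compound 4 `Cn1ccc2c(Oc3ccc(NC(=O)c4cc5cccnc5n(-c5ccccc5)c4=O)cc3F)ccnc21` differs from compound 1 by methyl in place of hydrogen on an aromatic nitrogen. Neither measured step bears on this place: both exchange a hydrogen on an aromatic carbon elsewhere in the shared core, one modestly lowering and one modestly raising the number. Going by the values given here, no step touches the aromatic nitrogen of the five-membered ring, so the direction is open and a step beyond the scatter either way is possible. Compound 4 is therefore estimated at 400 nM, with a range from 100 nM to 2000 nM. The expected step is a 2.5-fold higher number from compound 1 to compound 4 (0.40 log units; beyond the scatter).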

Compound 4, half-maximal inhibitory concentration: 510 nM
Estimate against measurement, compound 4: 1.3-fold (0.11 log units) below, and the stated range covers the measured number.
By their numbers in this assay, from the lowest: compound 2; then compound 1; then compounds 4 and 3 (each within the scatter of the next).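

In this assay the only change shown at this position gives a 3.2-fold higher number from compound 1 to compound 4 (0.50 log units; beyond the scatter) and so sets the direction there: methyl on the aromatic nitrogen of the five-membered ring goes with a weaker inhibitor than hydrogen does. This reading is modest in size and rests on a single pair. Nothing available explains the step. The compounds shown leave open whether ethyl or a longer chain ending in an amine on that nitrogen would move the number further. They also leave open whether methyl there would give a similar step on compound 2.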